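The source may hold more compounds than are shown below. What is called first, only, known or untested is meant among the compounds shown, and "the series" means these compounds.

Measured so far:

Compound 1, `CC(C)COc1ncc(-c2cn(C)c3cc(C(=O)NS(C)(=O)=O)ccc23)cc1Cl`, 100%
Compound 2, `CC(C)COc1ncc(-c2cn(C)c3cc(C(=O)NS(C)(=O)=O)c(F)cc23)cc1Cl`, 100%
Compound 3, `Cn1cc(-c2ccc(C(F)(F)F)cc2)c2cc(F)c(C(=O)NS(C)(=O)=O)cc21`, 95%

All three were tested in an ADME assay on microsomes from liver (Mus musculus) for metabolic stability, with a stated time of 10 min, tested at 0.5 uM; a lower number here means that less of the compound is left, a higher number that more of the compound is left. Compound 1 gives 100%, compound 2 gives 100% and compound 3 gives 95%; the three numbers lie within the scatter of one another, so no order among them can be read from these data.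

Compound 1 and compound 2 share a core and differ in one place: hydrogen in place of fluoro on an aromatic carbon. This change made the step of no change at the digits printed from compound 2 to compound 1 (within the scatter), so the fluoro contributed nothing measurable to how much compound was left in this assay.

Compound 4, `Cn1cc(-c2ccc(C(F)(F)F)cc2)c2ccc(C(=O)NS(C)(=O)=O)cc21`, has not yet been measured. It stands to compound 3 as compound 1 stands to compound 2, through the same kind of change: hydrogen in place of fluoro on an aromatic carbon. The two place descriptions match word for word, so the change is made at the same kind of position in both pairs. The cores of compound 3 and compound 2 differ, but that difference is not broken down here.

Since the same change produced no change at the digits printed from compound 2 to compound 1 (within the scatter), the step expected in this assay from compound 3 to compound 4 is no change at the digits printed from compound 3 to compound 4 (within the scatter), again within the scatter. Compound 4 is therefore estimated at 95%, with a range from 84% to 100%, because compound 3 gives 95%.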

Compound 4, percent of the compound remaining: 54%
Compound 4: the middle estimate sits 41 percentage points above what was measured; measured number below the stated range.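

In this assay, putting hydrogen in place of fluoro on the aromatic carbon ortho to the (methylsulfonyl)carbamoyl group gave a number 41 percentage points lower from compound 3 to compound 4 (beyond the scatter), so on this core the fluoro cannot be removed without a clear effect on how much compound is left. The same change, described in the same words, therefore cannot simply be carried from one core to another in this series, since its outcome differed between the two pairs: the same change on two cores in this assay, no change at the digits printed (within the scatter) from compound 2 to compound 1 and a number 41 percentage points lower (beyond the scatter) from compound 3 to compound 4, 41 percentage points apart, beyond the scatter of two such steps. For the compounds shown here, with only two pairs, this shows that the core can matter, but it does not show which part of the core decides the outcome, why the steps differ, or what the same change would do on any third core.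

The compounds shown leave open whether a different group at this place on the core of compound 4, such as chlorine, methyl or a nitrile, would behave as the fluoro does on the core of compound 3. They also leave open whether the step from fluoro to hydrogen would keep its size if a carboxylic acid stood in place of the (methylsulfonyl)carbamoyl group.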